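The source may report more compounds than this note shows. Statements on the series, on what has been measured and on what is new or still open speak of the compounds shown alone.

Measured so far:
compound 1 `O=C(Nc1cccc(-n2cc(-c3ccncc3)c(-c3cc(O)cc(Cl)c3)n2)c1)Nc1ccc(Cl)c(Cl)c1` — 54%
compound 2 `COc1cc(Cl)cc(-c2nn(-c3cccc(NC(=O)Nc4cc(C(F)(F)F)cc(C(F)(F)F)c4)c3)cc2-c2ccncc2)c1` — 22%

In a functional assay on CAKI-1 cells (Homo sapiens) for inhibition, read by sulforhodamine B assay, with a stated time of 48 h, tested at 1 uM (on this read-out higher numbers stand for a weaker effect at the one concentration tested and lower numbers for a stronger effect), compound 2 holds the lower of the two numbers, with compound 1 standing higher by a gap beyond the usual scatter. Compound 3 `COc1cc(Cl)cc(-c2nn(-c3cccc(NC(=O)Nc4cccc(C(F)(F)F)c4)c3)cc2-c2ccncc2)c1` differs from compound 2 by hydrogen in place of trifluoromethyl on an aromatic carbon. For the measured compounds named here, no measured step of this kind exists, so the size of the step is uncertain; the expectation is a shift toward a higher number, roughly the estimated step of a number 18 percentage points higher from compound 2 to compound 3 (beyond the scatter), which would lie beyond the scatter. Compound 3 is estimated at 40%, within a range from 20% to 65%.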

Compound 3, a percentage reported as activity, at one concentration (the size of the read-out at that concentration, not a potency): 57%
Compound 3: the middle estimate sits 17 percentage points below what was measured; the measured number falls inside the stated range.
By their numbers in this assay, from the lowest: compound 2; then compounds 1 and 3 (each within the scatter of the next).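

Within this assay, hydrogen in place of trifluoromethyl on this aromatic carbon gives a number 35 percentage points higher from compound 2 to compound 3 (beyond the scatter), the first measured step in the series, so the read-out at this one concentration responds strongly to the group at this position. The remaining trifluoromethyl group in compound 3 does not preserve the number held by compound 2. No measurement here gives a reason for the step. Only hydrogen and trifluoromethyl are shown at this carbon. On these data alone, whether a smaller group, such as a nitrile or an amine, would hold the lower number remains open.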